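A few compounds are considered here, and "the series" means these few. Any claim that something is new, unique, unknown or untested is made for them only; others in the source may bear on it.

Measured compounds:
Compound 1, `N/C(=N\NC(=S)N1CCSCC1)c1ccccn1`, gives 80.8% in a functional assay on A-431 cells (Homo sapiens) for cytotoxicity, read by MTT assay, with a stated time of 72 h, tested at 100 uM; a lower number here means less inhibition of growth, a higher number more inhibition of growth at the concentration tested.
Compound 2, `Cc1cccc(/C(N)=N/NC(=S)N2CCCC2)n1`, gives 86.8% in this assay.

Compound 2 holds the highest of the two numbers recorded so far in this assay. Its nearest neighbour is compound 1, whose number lies lower by a gap that falls within the usual scatter of repeated measurements, so the two values cannot be told apart and neither compound can be called the more active of the two.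

The next compound, compound 3, `N/C(=N\NC(=S)N1CCCC1)c1ccccn1`, has not yet been measured in this assay. Relative to compound 2 the change is hydrogen in place of methyl on an aromatic carbon. For the measured compounds named here, no step between measured compounds is on hand to show what the loss of a methyl at that position does, so the expectation rests on the small size of the change alone. Compound 3 is expected to stay close to compound 2, with a step of a number 3.8 percentage points lower from compound 2 to compound 3 (within the scatter) that does not go beyond the scatter in either direction. For compound 3 the estimate in this assay is 83%, with a range from 70% to 93%.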

Compound 3, percent growth inhibition at one concentration: 83.8%
The estimate for compound 3 lay 0.8 percentage points below the measured number; low and high end bracket the measured number.
By their numbers in this assay, from the lowest: compounds 1, 3 and 2 (each within the scatter of the next).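

In this assay, hydrogen in place of methyl on an aromatic carbon, next to the ring nitrogen and meta to a large group, gives a number 3 percentage points lower from compound 2 to compound 3 (within the scatter), so the methyl at this position is not needed to keep the number at this level. Pyrrolidin-1-yl in place of thiomorpholin-4-yl on a thiocarbonyl carbon gives a number 3 percentage points higher from compound 1 to compound 3 (within the scatter), so that exchange cannot be told from no change either. Compound 1 and compound 2 differ in both of these places, whereas compound 3 now lets each change be read alone, and neither moves the number beyond the scatter. Nothing on hand gives a reason for either result.

The compounds shown leave open whether a group other than methyl on that aromatic carbon, such as an amine, a methoxy group or a chlorine atom, would stay within the scatter of hydrogen. They also leave open whether an open-chain dimethylamino group on the thiocarbonyl carbon, in place of the two rings seen there so far, would give a number that can be told apart from those of compound 1 and compound 3.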